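The compounds below may be only part of what the source reports. "The series", "measured", "known", "first", "only" and "open" are said of these compounds alone.

Compound 1 `CNC(=O)[C@@]12C[C@@H]1[C@@H](n1cnc3c(NC4CC4c4cccc(F)c4)nc(C#Cc4ccccc4)nc31)[C@H](O)[C@@H]2O` and compound 2 `CNC(=O)[C@@]12C[C@@H]1[C@@H](n1cnc3c(NC4CC4c4cccc(Cl)c4)nc(C#Cc4ccccc4)nc31)[C@H](O)[C@@H]2O` share one core and differ only in the group carried on the phenyl ring. In an assay on CHO cells for displacement of a labelled ligand from adenosine receptor A1 (Homo sapiens), read by scintillation counting, with a stated time of 60 min, tested at 10 uM (a higher number here means more inhibition at the concentration tested (going by the name of the read-out), a lower number less inhibition), compound 1 gives 18%, while compound 2 gives 6%. For the measured compounds named here, of the two numbers measured, compound 2 stands lowest; its only neighbour is compound 1, and the step of a number 12 percentage points lower from compound 1 to compound 2 (beyond the scatter) ran downward beyond the scatter. Compound 3 `CNC(=O)[C@@]12C[C@@H]1[C@@H](n1cnc3c(NC4CC4c4cccc(Br)c4)nc(C#Cc4ccccc4)nc31)[C@H](O)[C@@H]2O` carries the series one halogen further, with bromo in place of chloro on an aromatic carbon. Going by the values given here, the single measured step that bears on this change, a number 12 percentage points lower from compound 1 to compound 2 (beyond the scatter), was modest and pointed downward, but it concerned a different pair of halogens, and nothing shows whether a second exchange of this kind continues in the same direction or levels off. Compound 3 is therefore expected to show a step of a number 2 percentage points lower from compound 2 to compound 3 (within the scatter), within the scatter. Compound 3 is estimated at 4% in this assay, with a range from -8% to 20%.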

Compound 3, a percentage reported as inhibition, at one concentration (the size of the read-out at that concentration, not a potency): 17%
Compound 3: the middle estimate sits 13 percentage points below what was measured; the measured number falls inside the stated range.
By their numbers in this assay, from the lowest: compound 2; then compounds 3 and 1 (each within the scatter of the next).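

In this assay, the step from chloro to bromo is a number 11 percentage points higher from compound 2 to compound 3 (beyond the scatter) and so runs against the earlier downward step, showing that the number at this place does not fall steadily along the halogens from fluoro through chloro to bromo. Exchanging fluoro directly for bromo gives a number 1 percentage points lower from compound 1 to compound 3 (within the scatter), which leaves these two halogens level, and the chloro compound, compound 2, alone stands apart from both. The data available offer no explanation for this turn at chloro.

On these data alone, it remains open whether iodo at this place would stay level with fluoro and bromo, and whether a non-halogen group such as methyl, methoxy or nitrile would do the same. As far as these compounds go, it also remains open whether the dip at chloro would recur on another core.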